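The source may report more compounds than this note shows. Statements on the series, on what has been measured and on what is new or still open speak of the compounds shown alone.

Compound 2 `CC/N=C(\NC#N)NCCSCCn1nc(-c2ccccc2)ccc1=O` is the reference for this step. In a functional assay on the whole organism (stomach) for inhibition, with Rattus norvegicus as the target, with a stated time of 4 h (a higher number here means that more compound is needed for the effect, a lower number that less compound is needed), compound 2 gives < 100 mg/kg, which is a limit of the assay and not a number. Among the measured compounds shown here, its one measured neighbour is compound 1 `C/N=C(\NC#N)NCCSCCn1nc(-c2ccccc2)ccc1=O`. In this assay compound 1 gives < 80 mg/kg, again a limit rather than a number. The step that the two limits leave unreadable from compound 1 to compound 2 therefore cannot be read, and the two limits the limit of < 100 mg/kg in this assay, at which 1 of the 2 values shown sits, and the limit of < 80 mg/kg in this assay, at which 1 of the 2 values shown sits, are all the series shows so far. Compound 3 `CCC/N=C(\NC#N)NCCSCCn1nc(-c2ccccc2)ccc1=O` differs from compound 2 by methyl in place of hydrogen on a saturated chain carbon, two bonds along the chain from a double-bonded nitrogen. For the measured compounds named here, no measured step in this assay bears on this change, since the only recorded step is unreadable. For compound 3 the expected step in this assay is a step that the limit leaves unreadable from compound 2 to compound 3, within the scatter. The estimate for compound 3 in this assay is 60 mg/kg, with a range from 20 mg/kg to 150 mg/kg, and a further limit instead of a number is a likely outcome.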

Compound 3, dose for half-maximal effect: > 100 mg/kg
Compound 3: no number, only a limit; the forecaster's own chance of this, stated with the estimate: 60%; middle value at least 1.6-fold (0.22 log units) away from the limit.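

With propyl at this position, on a saturated chain carbon two bonds along the chain from a double-bonded nitrogen, the series gains its first readable step in this assay: an at least 1.2-fold higher number from compound 1 to compound 3 (0.09 log units; that floor lies within the scatter). This step is only a floor, so it gives a direction between these two compounds and no size beyond the scatter. The ethyl to propyl change gives a number no lower from compound 2 to compound 3 (the limit leaves the size open). The remaining step cannot be read, and compound 3 stands at a limit, not a number: the limit of > 100 mg/kg in this assay, at which 1 of the 3 values shown sits.

Going by these compounds, the actual doses of all three compounds remain open, so the ethyl to propyl change has no size yet. Also open, on these data alone, is how a longer chain such as butyl, a branched chain such as isopropyl, or a chain ending in an amine would read at this position.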